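The source may hold more compounds than are shown below. What is called first, only, known or untested is meant among the compounds shown, and "the series" means these compounds.

Measured compounds:
- compound 1, `Cc1nc(N2CCN(C3CCCC3)CC2)nc2ccc(NC(=O)COc3ccc(Cl)cc3)cc12`: 96 nM
- compound 2, `Cc1nc(N2CCN(C3CCOCC3)CC2)nc2ccc(NC(=O)COc3ccc(Cl)cc3)cc12`: 45 nM
- compound 3, `CCN1CCN(c2nc(C)c3cc(NC(=O)COc4ccc(Cl)cc4)ccc3n2)CC1`: 690 nM

All three share the same core and differ only in the group carried by an amine nitrogen in a ring. In an assay on CHO-K1 cells for displacement of a labelled ligand from melanin-concentrating hormone receptor 1 (Homo sapiens), with a stated time of 2 h (on this read-out lower numbers stand for stronger inhibition and higher numbers for weaker inhibition), compound 3 gives 690 nM, the highest of the three numbers, so it is the weakest binder measured here. The two measured steps that lead to it both involve swapping a ring for a short chain on that nitrogen: a 7.2-fold higher number from compound 1 to compound 3 (0.86 log units; beyond the scatter) and a 15-fold higher number from compound 2 to compound 3 (1.19 log units; beyond the scatter). Both were beyond the scatter, and both went in the same direction, toward weaker binding as the ring was removed.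

Compound 4, `Cc1nc(N2CCN(C)CC2)nc2ccc(NC(=O)COc3ccc(Cl)cc3)cc12`, continues along the same line: hydrogen in place of methyl on a saturated chain carbon bound to an amine nitrogen in a ring. Among the compounds with values here, no measured step matches this exact change, and the steps that bear on it compared ring groups with ethyl rather than ethyl with methyl. Since shortening the group on this nitrogen has so far only raised the number, a further small rise is the plainest expectation, though one that may fall within the scatter. The expected step is a 1.6-fold higher number from compound 3 to compound 4 (0.20 log units; within the scatter). Compound 4 is estimated to give 1100 nM in this assay, with a likely range of 400 nM to 3500 nM.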

Compound 4, half-maximal inhibitory concentration: 220 nM
For compound 4 the middle estimate is 5.0-fold (0.70 log units) above the measured one, outside the stated range (below it).
By their numbers in this assay, from the lowest: compound 2; then compound 1; then compound 4; then compound 3.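

In this assay, trimming ethyl to methyl on the amine nitrogen in a ring gives a 3.1-fold lower number from compound 3 to compound 4 (0.50 log units; beyond the scatter) and so reverses the direction seen so far: a smaller group on this nitrogen does not always mean weaker binding, and compound 3, with its ethyl, has the highest number of the four. The two ring groups still outdo methyl, with a 4.9-fold higher number from compound 2 to compound 4 (0.69 log units; beyond the scatter) and a 2.3-fold higher number from compound 1 to compound 4 (0.36 log units; beyond the scatter) on this read-out, so the order runs oxan-4-yl, cyclopentyl, methyl, ethyl and does not follow group size in one direction. Nothing available here explains this reversal.

The compounds shown leave open what the nitrogen would give with only a hydrogen on it, and whether a longer chain such as propyl or butyl would sit nearer ethyl or nearer the ring groups. They also cannot separate the effect of having a ring from the effect of having more carbons, a question that a small ring such as cyclopropyl or a branched chain such as isopropyl could help answer.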